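Trifluoromethoxy for trifluoromethyl on a weakly inhibiting scaffold

The compounds below may be only part of what the source reports. "The series", "measured", "known", "first", "only" and "open" are said of these compounds alone.

Compound 1, `Oc1cccc(-c2cc(-c3ccc(C(F)(F)F)cc3)cc(-c3cccc(O)c3)n2)c1`: reported only as a limit, > 50000 nM
Compound 2, `Oc1ccc(-c2cc(-c3ccc(C(F)(F)F)cc3)cc(-c3cccc(O)c3)n2)cc1`: 17300 nM
Compound 3, `Oc1ccc(-c2cc(-c3ccc(C(F)(F)F)cc3)cc(-c3ccc(O)cc3)n2)cc1`: reported only as a limit, > 50000 nM

Among the measured compounds shown here, in a functional assay on HeLa cells (Homo sapiens) for inhibition (on this read-out higher numbers stand for weaker inhibition and lower numbers for stronger inhibition), compound 2 holds the only real number of the three. Compound 1 and compound 3 each sit at a limit of the assay, (the limit of > 50000 nM in this assay, at which 2 of the 3 values shown sit). The two measured steps, an at least 2.8-fold lower number from compound 1 to compound 2 (0.46 log units; beyond the scatter) and an at least 2.8-fold higher number from compound 2 to compound 3 (0.46 log units; beyond the scatter), both concern a hydroxyphenyl group.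

Compound 4, `Oc1ccc(-c2cc(-c3ccc(OC(F)(F)F)cc3)cc(-c3cccc(O)c3)n2)cc1`, differs from compound 2 in another place: trifluoromethoxy in place of trifluoromethyl on an aromatic carbon. Neither measured step touches this group, so no step beyond the scatter is expected; the estimate means a 1.2-fold higher number from compound 2 to compound 4 (0.06 log units; within the scatter). Compound 4 is therefore expected to give about 20000 nM, in a range from 6000 nM to 60000 nM.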

Compound 4, half-maximal inhibitory concentration: 27800 nM
Estimate against measurement, compound 4: 1.4-fold (0.14 log units) below; the range from low to high includes it.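

In this assay trifluoromethoxy in place of trifluoromethyl gives a 1.6-fold higher number from compound 2 to compound 4 (0.21 log units; within the scatter) and so makes no clear difference. Among the compounds shown here, this is the first step here between two real numbers, and it shows that this position, para to a large group, accepts the change without a shift beyond the scatter. The earlier steps shown here each rest on a limit rather than a number: the limit of > 50000 nM in this assay, at which 2 of the 4 values shown sit.

Going by these compounds, whether an amine or a carboxylic acid at this position would move the number beyond the scatter remains open. So does whether any group here could give clearly stronger inhibition than compound 2.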